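The compounds below may be only part of what the source reports. "The series", "measured", "known", "first", "only" and "open" are said of these compounds alone.

In a physicochemical assay for solubility (a lower number here means a less soluble compound, a higher number a more soluble compound), compound 1 (`COc1ccc(-n2cnc3cnc(-c4ccccc4C)cc32)cc1OC`) gives > 200000 nM, which is a limit. Compound 2 (`COc1ccc(-n2cnc3cnc(-c4ccc(F)cc4C)cc32)cc1OC`) gives > 200000 nM, also a limit, so it has no number of its own. It stands at the limit of > 200000 nM in this assay, at which 2 of the 3 values shown sit. Compound 3 (`COc1ccc(-n2cnc3cnc(-c4ccc(F)cc4OC)cc32)cc1OC`) gives 42000 nM.

Compound 4 (`COc1ccc(-n2cnc3cnc(-c4ccc(F)cc4C)cc32)cc1F`) has fluoro in place of methoxy on an aromatic carbon, ortho to a methoxy group: fluoro in place of methoxy on an aromatic carbon. Among the measured compounds shown here, no measured step covers this change at that place. The fluoro step shows a step that the two limits leave unreadable from compound 1 to compound 2. For the measured compounds named here, the only readable guides are an at least 4.7-fold lower number from compound 1 to compound 3 (0.67 log units; beyond the scatter) and an at least 4.7-fold lower number from compound 2 to compound 3 (0.67 log units; beyond the scatter), both at another place, so they give only a rough scale.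

A modest fall is expected, as an at least 2.0-fold lower number from compound 2 to compound 4 (0.30 log units; that floor lies within the scatter), though a result at the limit would not be a surprise. For compound 4 the estimated value is 100000 nM, with an expected range of 30000 nM to 200000 nM.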

Compound 4, solubility: 49000 nM
For compound 4 the middle estimate is 2.0-fold (0.31 log units) above the measured one; the measured number falls inside the stated range.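

Fluoro in place of methoxy, ortho to a methoxy group, gives in this assay an at least 4.0-fold lower number from compound 2 to compound 4 (0.61 log units; beyond the scatter). The read-out therefore responds to a change at this position, whereas the readable steps among compound 1, compound 2 and compound 3 lay at another place. The size is only a floor, since compound 2 stands at a limit: the limit of > 200000 nM in this assay, at which 2 of the 4 values shown sit.

Going by these compounds, whether the lower number follows from losing the methoxy or from gaining the fluoro remains open. On these data alone, how an amine or a carboxylic acid at this position would read in this assay is also open.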